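The source may hold more compounds than are shown below. What is called first, only, known or untested is meant among the compounds shown, and "the series" means these compounds.

Values in a functional assay on MCF7 cells (Homo sapiens) for cytotoxicity, read by MTT assay (a lower number here means a stronger inhibitor, a higher number a weaker inhibitor), are as follows.
Compound 1 `COc1ccc(OC)c(C(=O)/C=C/c2ccco2)c1` gives 10500 nM
Compound 2 `COc1ccc(OC)c(C(=O)/C=C/c2ccsc2)c1` gives 3700 nM
Compound 3 `COc1ccc(OC)c(C(=O)/C=C/c2ccc(C)o2)c1` gives 10300 nM

Compound 1 sits at the weak end of this small set, level with compound 3 and clearly above compound 2. Compound 4 `COc1ccc(OC)c(C(=O)/C=C/c2sccc2C)c1` changes only the ring on the chain, with 3-methylthiophen-2-yl in place of furan-2-yl on a double-bonded chain carbon bound to a double-bonded chain carbon as the whole difference. Among the compounds with values here, two measured steps bear on this. Changing the ring to thiophen-3-yl gave a 2.8-fold lower number from compound 1 to compound 2 (0.45 log units; beyond the scatter) as a modest shift. Adding a methyl on an aromatic carbon gave a 1.0-fold lower number from compound 1 to compound 3 (0.01 log units; within the scatter) within the scatter. Within the data shown here, no measured compound carries 3-methylthiophen-2-yl itself, so this reading is uncertain. A modest step is therefore expected, estimated as a 2.1-fold lower number from compound 1 to compound 4 (0.32 log units; beyond the scatter) in this assay terms. For compound 4 the estimated value is 5000 nM (expected range 2000 nM to 12000 nM).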

Compound 4, half-maximal inhibitory concentration: 7600 nM
Compound 4: middle estimate off by 1.5-fold (0.18 log units), on the low side; low and high end bracket the measured number.
By their numbers in this assay, from the lowest: compound 2; then compounds 4, 3 and 1 (each within the scatter of the next).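

In this assay, 3-methylthiophen-2-yl on this chain carbon stays level with both furan rings (a 1.4-fold lower number from compound 1 to compound 4 (0.14 log units; within the scatter); a 1.4-fold lower number from compound 3 to compound 4 (0.13 log units; within the scatter)). It does not match thiophen-3-yl, however (a 2.1-fold higher number from compound 2 to compound 4 (0.31 log units; beyond the scatter)), so among these compounds a sulfur-containing ring alone does not give the number of compound 2. No available evidence accounts for this gap.

Open, going by these compounds, is how thiophen-2-yl without its methyl would compare, so the effects of ring attachment and methyl remain tangled. Also open, on these data alone, is how a ring carrying an amine or a carboxylic acid would behave here.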